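Chlorophenyl change from compound 3 to compound 4

This account rests on a few compounds, and the source may have more. Where it says the series, first, only, none or still open, it means among the compounds named here.

Measured in a functional assay on NCI/ADR-RES cells (Homo sapiens) for inhibition, read by sulforhodamine B assay, with a stated time of 48 h; a lower number here means a stronger inhibitor of growth, a higher number a weaker inhibitor of growth:
compound 1 `CC1=CC[C@H](C(C)(C)NC(=S)N/N=C/c2ccccc2)CC1` — > 100000 nM
compound 2 `CC1=CC[C@H](C(C)(C)NC(=S)N/N=C/c2ccccc2O)CC1` — 3700 nM
compound 3 `CC1=CC[C@H](C(C)(C)NC(=S)N/N=C/c2ccccc2Cl)CC1` — 75000 nM

The number for compound 1 is only a limit of the assay, (the limit of > 100000 nM in this assay, at which 1 of the 3 values shown sits). Compound 3 stands highest of the two numbers given; its nearest neighbour is compound 2, a 20-fold higher number from compound 2 to compound 3 (1.31 log units; beyond the scatter). Against the limit of compound 1, an at least 1.3-fold lower number from compound 1 to compound 3 (0.12 log units; that floor lies within the scatter).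

Compound 4 `CC1=CC[C@H](C(C)(C)NC(=S)N/N=C/c2ccc(Cl)cc2)CC1` differs from compound 3 by 4-chlorophenyl in place of 2-chlorophenyl on a carbon with a double bond to nitrogen. Among the compounds with values here, no measured step changes where the chloro sits on the ring; the known steps concern hydroxy or chloro in place of hydrogen, an at least 27-fold lower number from compound 1 to compound 2 (1.43 log units; beyond the scatter) and an at least 1.3-fold lower number from compound 1 to compound 3 (0.12 log units; that floor lies within the scatter), and the chloro step lies within the scatter. For compound 4 the expected step is therefore none beyond the scatter, a 1.5-fold lower number from compound 3 to compound 4 (0.18 log units; within the scatter). The expected value for compound 4 is 50000 nM, within 15000 nM to 150000 nM.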

Compound 4, concentration for 50% growth inhibition: 65200 nM
Beside the measured number, compound 4's estimate is 1.3-fold (0.12 log units) below it, and the stated range covers the measured number.
By their numbers in this assay, from the lowest: compound 2; then compounds 4 and 3 (each within the scatter of the next). At a limit, above all of these: compound 1.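

The 4-chlorophenyl and 2-chlorophenyl groups cannot be told apart in this assay, with a 1.2-fold lower number from compound 3 to compound 4 (0.06 log units; within the scatter). Neither chloro placement comes near the 2-hydroxyphenyl group, with an 18-fold higher number from compound 2 to compound 4 (1.25 log units; beyond the scatter), so moving the chloro on the ring does not close that gap. The remaining step starts from a limit and gives only a floor, an at least 1.5-fold lower number from compound 1 to compound 4 (0.18 log units; that floor lies within the scatter): the limit of > 100000 nM in this assay, at which 1 of the 4 values shown sits.

Still open, from the compounds shown here alone, is whether the result for the 2-hydroxyphenyl group depends on the hydroxy itself, which a methoxy or an amine on the aromatic ring would test. Going by these compounds, the effect of the hydroxy's place on the ring also remains open.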